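This account rests on a few compounds, and the source may have more. Where it says the series, first, only, none or still open, it means among the compounds named here.

Three compounds have been measured in an assay on isolated protein for inhibition of Leucine-rich repeat serine/threonine-protein kinase 2 variant G2019S (Homo sapiens), read by TR-FRET and LanthaScreen, with stated times of 50 min and 30 min, in the presence of a further agent that is not named here; a higher number here means a weaker inhibitor, a lower number a stronger inhibitor:

Compound 1 `Cc1c(Nc2nc(N)c3c(C#N)c(N4CCC[C@H]4C)n(C)c3n2)cnn1C`: 43 nM
Compound 2 `Cc1c(Nc2nc(N)c3c(C#N)c(N4CCC[C@H]4C)n(C)c3n2)cnn1[C@H]1CCOC1`: 14 nM
Compound 3 `Cc1c(Nc2nc(N)c3c(C#N)c(N4CCC[C@H]4C)n(C)c3n2)cnn1CC(C)(C)O`: 35 nM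

Among these three, compound 1 gives the highest number in this assay; its nearest neighbour is compound 3, at a 1.2-fold lower number from compound 1 to compound 3 (0.09 log units; within the scatter), and the furthest is compound 2, at a 3.1-fold lower number from compound 1 to compound 2 (0.49 log units; beyond the scatter). Compound 3 and compound 2 are separated by a 2.5-fold higher number from compound 2 to compound 3 (0.40 log units; beyond the scatter).

Compound 4 `Cc1nn(C)cc1Nc1nc(N)c2c(C#N)c(N3CCC[C@H]3C)n(C)c2n1` is the next compound to be measured in this assay. It differs from compound 1 only in the pyrazole ring that carries the amino link to the shared core: 1,3-dimethyl-1H-pyrazol-4-yl in place of 1,5-dimethyl-1H-pyrazol-4-yl on a nitrogen on an aromatic ring. The two have the same atoms, joined differently.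

Among the compounds with values here, none of the measured steps touches this part of the molecule. The three steps known so far all change the group on the aromatic nitrogen of the pyrazole, and the largest of them, a 3.1-fold lower number from compound 1 to compound 2 (0.49 log units; beyond the scatter), was still modest. Moving a methyl from one position of the same ring to another is a change of a different kind, with no direct precedent here, so the expectation for this assay is a step of no clear direction and of size not beyond the scatter, with wide uncertainty. The estimate for compound 4 is therefore 50 nM, with a range from 15 nM to 170 nM, which corresponds to an expected step of a 1.2-fold higher number from compound 1 to compound 4 (0.07 log units; within the scatter).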

Compound 4, half-maximal inhibitory concentration: 30 nM
For compound 4 the middle estimate is 1.7-fold (0.22 log units) above the measured one, within the range that was stated.
By their numbers in this assay, from the lowest: compound 2; then compounds 4, 3 and 1 (each within the scatter of the next).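

In this assay, replacing 1,5-dimethyl-1H-pyrazol-4-yl with 1,3-dimethyl-1H-pyrazol-4-yl gives a step (a 1.4-fold lower number from compound 1 to compound 4 (0.16 log units; within the scatter)) that cannot be distinguished from the ordinary variation between repeated measurements. Within the data shown here, this is the first change to show that the pyrazole can be rearranged, rather than only given a new group on its aromatic nitrogen, without a measurable effect on the number in this assay: the two compounds contain the same atoms, joined differently, and the assay treats them alike within its scatter. No supporting measurement is available to explain this outcome.

The data leave open whether this tolerance extends to groups larger than methyl on the pyrazole, such as ethyl, cyclopropyl or trifluoromethyl, or to a 1-methyl-1H-pyrazol-4-yl group carrying only the single methyl. It is also unknown whether the oxolan-3-yl group, which gave the one clear gain on the aromatic nitrogen (a 3.1-fold lower number from compound 1 to compound 2 (0.49 log units; beyond the scatter)), would give a similar step when paired with the 1,3-dimethyl arrangement of methyl and ring carbon.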